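One Side Chain Swapped on a Shared Cyclic Core

The source may report more compounds than this note shows. Statements on the series, on what has been measured and on what is new or still open speak of the compounds shown alone.

Measured so far in a functional assay, tested at 2.5 mM; a higher number here means more inhibition at the concentration tested (going by the name of the read-out), a lower number less inhibition:
compound 1 `CC(C)C[C@@H]1NC(=O)[C@H](Cc2cnc[nH]2)NC1=O` gives 83.9%
compound 2 `CC(C)C[C@@H]1NC(=O)[C@H](CC(=O)O)NC1=O` gives 95%
compound 3 `CC(C)C[C@@H]1NC(=O)[C@H](CCC(N)=O)NC1=O` gives 19%

Compound 1 stands second highest of these three numbers. Its nearest neighbour is compound 2, reached by a number 11.1 percentage points higher from compound 1 to compound 2 (beyond the scatter), a modest rise beyond the scatter. Its furthest is compound 3, reached by a number 64.9 percentage points lower from compound 1 to compound 3 (beyond the scatter), a large fall. Between the two others lies a number 76 percentage points lower from compound 2 to compound 3 (beyond the scatter), also large.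

The new compound 4 `CSCC[C@@H]1NC(=O)[C@H](CC(C)C)NC1=O` differs from compound 1 in one place: (methylsulfanyl)methyl in place of 1H-imidazol-5-yl on a saturated chain carbon bound to a saturated ring carbon. None of the three measured steps makes this exact change; each of them put in a group with a carbonyl, whereas the entering group here carries a sulfur and no ring. The two steps starting from compound 1 went in opposite directions, one modestly up and one sharply down, so the measured data leave the direction of this step open and the spread wide.

On that basis compound 4 is expected to give about 50% in this assay, within a range from 15% to 88%. This estimate corresponds to a number 33.9 percentage points lower from compound 1 to compound 4 (beyond the scatter), a drop that is only a cautious middle guess.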

Compound 4, a percentage reported as inhibition, at one concentration (the size of the read-out at that concentration, not a potency): 79%
The estimate for compound 4 lay 29 percentage points below the measured number, and the stated range covers the measured number.
By their numbers in this assay, from the lowest: compound 3; then compounds 4 and 1 (each within the scatter of the next); then compound 2.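

Placing a 2-(methylsulfanyl)ethyl chain where compound 1 carries (1H-imidazol-5-yl)methyl gives a number 4.9 percentage points lower from compound 1 to compound 4 (within the scatter) in this assay, so at this position a high number does not depend on a five-membered aromatic ring or a hydrogen-bond donor in the group. Before this result, the only other high number on the shared core came from the carboxy-bearing compound 2, while compound 3 with its carbamoyl group gave a low one, and a side chain with no carbonyl had not yet appeared in the series. Against that background, a number 16 percentage points lower from compound 2 to compound 4 (beyond the scatter) is a modest gap and a number 60 percentage points higher from compound 3 to compound 4 (beyond the scatter) is a large one, which leaves compound 3 as the low outlier among these four, though nothing shown explains why these side chains give the numbers they do.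

Going by these compounds, whether the sulfur itself counts stays open, as a plain pentyl chain or a sulfur-free ether chain would be needed to separate it from chain length alone. On these data alone, it is equally open how a primary amine on a longer chain, or a phenyl ring in place of the imidazole, would read at this position.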